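This account rests on a few compounds, and the source may have more. Where it says the series, first, only, none or still open, it means among the compounds named here.

Measured compounds:
Compound 1 `N#CC1=C(N)Oc2c(c3nc4ccccc4nc3c3ccccc23)C12C(=O)N(Cc1cnnn1-c1cccc(Br)c1)c1ccccc12` gives in a functional assay on HCT-116 cells (Homo sapiens) for antiproliferative activity, read by MTT assay, with a stated time of 48 h (a higher number here means a weaker inhibitor, a lower number a stronger inhibitor), a limit of the assay, > 50000 nM.
Compound 2 `COc1ccccc1-n1nncc1CN1C(=O)C2(C(C#N)=C(N)Oc3c2c2nc4ccccc4nc2c2ccccc32)c2ccccc21` gives a limit of the assay, > 50000 nM.
Compound 3 `N#CC1=C(N)Oc2c(c3nc4ccccc4nc3c3ccccc23)C12C(=O)N(Cc1cnnn1-c1cccc(S(N)(=O)=O)c1)c1ccccc12` gives 11300 nM.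

Among the measured compounds shown here, compound 3 thus holds the only plain number; the other two sit at the limit of > 50000 nM in this assay, at which 2 of the 3 values shown sit. Compound 4 `N#CC1=C(N)Oc2c(c3nc4ccccc4nc3c3ccccc23)C12C(=O)N(Cc1cnnn1-c1cc(Cl)ccc1Cl)c1ccccc12` differs from compound 3 by 2,5-dichlorophenyl in place of 3-sulfamoylphenyl on an aromatic nitrogen. For the measured compounds named here, two steps bear on this: an at least 4.4-fold lower number from compound 1 to compound 3 (0.64 log units; beyond the scatter) and an at least 4.4-fold lower number from compound 2 to compound 3 (0.64 log units; beyond the scatter), both at least modest and both ending at the sulfamoylphenyl. Compound 4 carries a dichlorophenyl, closer to compound 1 than to compound 3, so the step is expected to reverse: a 3.5-fold higher number from compound 3 to compound 4 (0.55 log units; beyond the scatter). Compound 4 is therefore estimated at 40000 nM, in the range 12000 nM to 80000 nM, and may well come back only as a limit.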

Compound 4, half-maximal inhibitory concentration: > 50000 nM
Compound 4: only a limit was reported (the forecaster's own chance of this, stated with the estimate: 55%); middle value at least 1.2-fold (0.09 log units) from the limit.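

The exchange of 3-sulfamoylphenyl for 2,5-dichlorophenyl on the aromatic nitrogen gives an at least 4.4-fold higher number from compound 3 to compound 4 (0.64 log units; beyond the scatter). The 2,5-dichlorophenyl group thus joins 3-bromophenyl and 2-methoxyphenyl, leaving compound 3 as the only one of the four with a plain number: the limit of > 50000 nM in this assay, at which 3 of the 4 values shown sit. The steps among compound 1, compound 2 and compound 4 cannot be read, since all three values are limits. From the compounds shown here alone, it remains open whether an amine or a carboxylic acid in place of the sulfamoyl group would also give a plain number. Going by these compounds, whether the sulfamoyl group would keep its effect on a differently substituted phenyl ring is also open.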